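This account rests on a few compounds, and the source may have more. Where it says the series, first, only, none or still open, it means among the compounds named here.

In an ADME assay on microsomes from liver (Mus musculus) for metabolic stability, read by LC-MS, with a stated time of 10 min (on this read-out higher numbers stand for a more stable compound and lower numbers for a less stable compound), compound 1 `CN(C[C@H]1Cc2c(cccc2N2CCN3CCC[C@H]3C2)CN1)[C@H]1CCCc2cccnc21` gives 40.1% as its reading, within the scatter of compound 2 `CN(C[C@H]1Cc2c(cccc2N2CCN(Cc3ccccn3)CC2)CN1)[C@H]1CCCc2cccnc21` at 40.4% on the same read-out, while compound 3 `CCCN(C[C@H]1Cc2c(cccc2N2CCNCC2)CN1)[C@H]1CCCc2cccnc21` reaches 87.4% on that read-out, well beyond the scatter from both. In compound 4 `CN(C[C@H]1Cc2c(cccc2N2C[C@H]3C[C@@H]2CN3)CN1)[C@H]1CCCc2cccnc21` the core of compound 1 stays and a group of 7 heavy atoms (5 carbon, 2 nitrogen; 2 five-membered non-aromatic rings with 1 hetero atom each) in place of a group of 9 heavy atoms (7 carbon, 2 nitrogen; one five-membered non-aromatic ring with 1 hetero atom, one six-membered non-aromatic ring with 2 hetero atoms), on an aromatic carbon is the whole change. Among the measured compounds shown here, no measured pair isolates such a change. The nearest pointer is compound 3 at 87.4% with a hydrogen-bond donor in the group at that place, although it also differs from compound 1 elsewhere. In this assay an upward step of moderate size is expected, with a number 24.9 percentage points higher from compound 1 to compound 4 (beyond the scatter) as the estimate for it. Compound 4 is estimated at 65% as its reading, with an expected range from 42% to 88% around it.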

Compound 4, percent of the compound remaining: 95.9%
Compound 4: the middle estimate sits 30.9 percentage points below what was measured, and the stated range ends below it.
By their numbers in this assay, from the lowest: compounds 1 and 2 (each within the scatter of the next); then compounds 3 and 4 (each within the scatter of the next).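

With the core of compound 1 unchanged, replacing the group of 9 heavy atoms on the aromatic carbon with the group of 7 heavy atoms gives a number 55.8 percentage points higher from compound 1 to compound 4 (beyond the scatter) in this assay, a large step. Among the compounds shown here, this is the first pair that differs in this one place, and it shows that the group at this position alone can strongly shift the reading. The entering group has 1 hydrogen-bond donor and the leaving group has 0, but no measurement here explains the step. Going by these compounds, it remains open how a morpholine or an open-chain primary amine on this aromatic carbon would read.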